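Thiophen-3-yl to 5-methoxythiophen-2-yl: working notes

This account rests on a few compounds, and the source may have more. Where it says the series, first, only, none or still open, it means among the compounds named here.

Measured in a functional assay on MES-SA cells (Homo sapiens) for antiproliferative activity, read by resazurin assay, with a stated time of 72 h (a higher number here means a weaker inhibitor, a lower number a stronger inhibitor), so far:
- compound 1 `COc1cc(/C=C\c2cc3ccccc3s2)cc(OC)c1OC` gives 13 nM as its result
- compound 2 `COc1cc(/C=C\c2ccsc2)cc(OC)c1OC` gives "not determined" (no result reported) as its result

Compound 2 has no number and so holds no place on the scale, which leaves compound 1 as the only measured anchor. Next comes compound 3 `COc1ccc(/C=C\c2cc(OC)c(OC)c(OC)c2)s1`. The structural change 5-methoxythiophen-2-yl in place of thiophen-3-yl on a double-bonded chain carbon bound to a double-bonded chain carbon puts 5-methoxythiophen-2-yl in place of thiophen-3-yl on a double-bonded chain carbon bound to a double-bonded chain carbon. Among the compounds with values here, no step in this assay can be measured from compound 2, so the expectation leans on compound 1 at 13 nM and is for a moderate step towards weaker inhibition relative to that compound. The estimated value for compound 3 is 35 nM with an expected range of 7 nM to 200 nM in this assay for now.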

Compound 3, half-maximal inhibitory concentration: 53 nM
Estimate against measurement, compound 3: 1.5-fold (0.18 log units) below; measured number inside the range.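

No new step can be read, as compound 2 holds no single number in this assay and so compound 3 cannot be set against it. The compounds shown leave open how thiophen-3-yl and 5-methoxythiophen-2-yl compare in this assay on an otherwise shared core. No evidence bears on this result.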